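The source may report more compounds than this note shows. Statements on the series, on what has been measured and on what is new or still open speak of the compounds shown alone.

Measured so far in a functional assay on EA.hy 926 cells (Homo sapiens) for cytotoxicity, read by MTT assay, with stated times of 24 h and 12 h; a higher number here means that more compound is needed for the effect, a lower number that less compound is needed:
compound 1, `COc1ccc(OC(=O)c2nc(C)c(C)nc2C)c(/C=C/C(=O)O)c1`, gives 48600 nM
compound 2, `CCOC(=O)/C=C/c1cc(OC)ccc1OC(=O)c1nc(C)c(C)nc1C`, gives 105000 nM
compound 3, `Cc1nc(C)c(C(=O)Oc2cccc(/C=C/C(=O)O)c2)nc1C`, gives 24000 nM

Compound 2 differs from compound 1 in a single place: ethyl in place of hydrogen on an oxygen next to a carbonyl group. That change produced a 2.2-fold higher number from compound 1 to compound 2 (0.33 log units; beyond the scatter). The core of compound 3 differs from the core of compound 1, but that difference is not broken down here; among the three measured compounds, compound 3 has the lowest number, and both compound 1 and compound 2 stand beyond the scatter above it.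

Compound 4, `CCOC(=O)/C=C/c1cccc(OC(=O)c2nc(C)c(C)nc2C)c1`, is still to be measured. It differs from compound 3 by ethyl in place of hydrogen on an oxygen next to a carbonyl group, the same change that separates compound 1 from compound 2, at a place described in exactly the same words. Among the measured compounds shown here, for compound 4 the expected step in this assay is a 2.2-fold higher number from compound 3 to compound 4 (0.34 log units; beyond the scatter), which rests on a 2.2-fold higher number from compound 1 to compound 2 (0.33 log units; beyond the scatter), the only measured instance of this change. The estimate for compound 4 is 53000 nM, with a likely range from 25000 nM to 110000 nM.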

Compound 4, half-maximal effective concentration: 92600 nM
Estimate against measurement, compound 4: 1.7-fold (0.24 log units) below; the measured number falls inside the stated range.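

In this assay, ethyl in place of hydrogen on the oxygen of the carboxy group again gave a higher number, here a 3.9-fold higher number from compound 3 to compound 4 (0.59 log units; beyond the scatter). The two instances point the same way and do not differ in size beyond what repeated measurements allow: the same change on two cores in this assay, a 2.2-fold higher number (0.33 log units; beyond the scatter) from compound 1 to compound 2 and a 3.9-fold higher number (0.59 log units; beyond the scatter) from compound 3 to compound 4, 1.8-fold (0.25 log units) apart, within the scatter of two such steps. The change therefore carried over from one core to the other in direction and, within the scatter, in size, but two cores do not establish a rule for the whole series, and these numbers do not show why the number rises.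

The compounds shown leave open whether methyl, a longer chain such as butyl, or an amide in place of the ethoxycarbonyl group would give a similar step on either core.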